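The source may report more compounds than this note shows. Statements on the series, on what has been measured and on what is new or still open speak of the compounds shown alone.

Measured compounds:
- compound 1, `COc1ccccc1-c1nnc(-c2ccc(C(=O)N/N=C/c3cc(O)ccc3O)cc2)o1`: 100000 nM
- compound 2, `COc1ccccc1-c1nnc(-c2ccc(C(=O)N/N=C/c3cccc(O)c3)cc2)o1`: 398000 nM
- compound 3, `COc1ccc(/C=N/NC(=O)c2ccc(-c3nnc(-c4ccccc4OC)o3)cc2)c(O)c1`: 308000 nM

All three share one core and differ only in the ring that hangs from the carbon with a double bond to nitrogen. In an ADME assay on THP-1 cells (Homo sapiens) for cytotoxicity (a lower number here means a stronger inhibitor, a higher number a weaker inhibitor), compound 1 gives the lowest of the three numbers; compound 3 stands nearest, compound 2 furthest, and both gaps lie beyond the scatter.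

Compound 4, `COc1ccccc1-c1nnc(-c2ccc(C(=O)N/N=C/c3ccc(O)cc3O)cc2)o1`, has not yet been measured. It differs from compound 1 in one place:

2,4-dihydroxyphenyl in place of 2,5-dihydroxyphenyl on a carbon with a double bond to nitrogen

For the measured compounds named here, two measured steps bear on this change. Removing a hydroxy altogether gave a 4.0-fold higher number from compound 1 to compound 2 (0.60 log units; beyond the scatter). Keeping a hydroxy at position 2 but putting a methoxy at position 4 gave a 3.1-fold higher number from compound 1 to compound 3 (0.49 log units; beyond the scatter). Compound 4 keeps two hydroxy groups, as compound 1 does, so the change is smaller than either of those steps; yet it shares with compound 3 the pattern of a group at position 2 and another at position 4. A modest rise in this assay is therefore expected, smaller than the step to compound 3 and probably near the edge of the scatter.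

For compound 4 the expected step is a 2.0-fold higher number from compound 1 to compound 4 (0.30 log units; within the scatter), giving an estimated value of 200000 nM with a range from 100000 nM to 400000 nM.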

Compound 4, half-maximal inhibitory concentration: 104000 nM
Compound 4: middle estimate off by 1.9-fold (0.28 log units), on the high side; the range from low to high includes it.
By their numbers in this assay, from the lowest: compounds 1 and 4 (each within the scatter of the next); then compounds 3 and 2 (each within the scatter of the next).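

In this assay, shifting one hydroxy on the ring, so that 2,4-dihydroxyphenyl stands in place of 2,5-dihydroxyphenyl on a carbon with a double bond to nitrogen, gives a 1.0-fold higher number from compound 1 to compound 4 (0.02 log units; within the scatter) and leaves the two arrangements indistinguishable in this test. The arrangement shared by 2,4-dihydroxyphenyl and 2-hydroxy-4-methoxyphenyl alone therefore does not carry the higher number of compound 3: hydrogen in place of methyl on an oxygen on an aromatic ring gives a 3.0-fold lower number from compound 3 to compound 4 (0.47 log units; beyond the scatter) with no other change, and 2,4-dihydroxyphenyl in place of 3-hydroxyphenyl gives a 3.8-fold lower number from compound 2 to compound 4 (0.58 log units; beyond the scatter) on the same core. Across these four compounds, then, the two dihydroxyphenyl compounds, compound 1 and compound 4, sit together, while compound 2 and compound 3, each with a single free hydroxy, sit apart at higher numbers, and none of the four goes against this.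

Still open, from the compounds shown here alone, is how a ring carrying an amine or a carboxylic acid in place of a hydroxy would read in this assay and whether a 3,4-dihydroxyphenyl would fall with compound 1 and compound 4. Nothing measured in these compounds explains the grouping.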